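A few compounds are considered here, and "the series" means these few. Any claim that something is new, unique, unknown or untested is made for them only; others in the source may bear on it.

Within the data shown here, in an ADME assay on cells (Homo sapiens) for cytotoxicity, read by resazurin assay, with a stated time of 5 days (on this read-out higher numbers stand for lower toxicity in this test and lower numbers for higher toxicity in this test), no compound so far gives a number. Compound 1 (`COc1ccc(-c2nc(COc3cccc(Cl)c3)nc3ccsc23)cn1`) reads > 50000 nM as a limit of the assay. Compound 2 (`COc1ccc(-c2nc(C(C)S(=O)(=O)c3cccc(Cl)c3)nc3ccsc23)cn1`) reads > 50000 nM as a limit too. Compound 3 (`COc1ccc(-c2nc(CS(=O)(=O)c3cccc(Cl)c3)nc3ccsc23)cn1`) stands at > 10000 nM which is likewise a limit and not a number. Compound 4 (`O=c1ccc(-c2nc(CS(=O)(=O)c3cccc(Cl)c3)nc3ccsc23)c[nH]1`) differs from compound 3 by one swap on an aromatic carbon (a group of 7 heavy atoms (5 carbon, 1 nitrogen, 1 oxygen; one six-membered aromatic ring with 1 hetero atom) in place of a group of 8 heavy atoms (6 carbon, 1 nitrogen, 1 oxygen; one six-membered aromatic ring with 1 hetero atom), on an aromatic carbon). Among the measured compounds shown here, the only measured step is a step that the two limits leave unreadable from compound 2 to compound 3 and it puts hydrogen in place of methyl on a saturated chain carbon, not on this group, so it offers no size to carry over. The expected step in this assay is a step that the limit leaves unreadable from compound 3 to compound 4 with no firm direction estimated. For compound 4 the estimated value is 30000 nM with an expected range from 10000 nM to 50000 nM for this measurement.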

Compound 4, half-maximal cytotoxic concentration: > 50000 nM
Compound 4 ended at the assay's limit (the forecaster's own chance of this, stated with the estimate: 75%); middle value at least 1.6-fold (0.22 log units) away from the limit.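

Compound 3 and compound 4 both read only as limits in this assay, and the step between them cannot be read. The compounds shown leave open at what concentration any of them harms these cells, and whether replacing the 6-methoxypyridin-3-yl group changes that concentration.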